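This account rests on a few compounds, and the source may have more. Where it says the series, first, only, none or still open, it means among the compounds named here.

Compound 1 `Cc1cc(NCc2ccccn2)n2nc(C)c(-c3ccc(F)cc3)c2n1`, compound 2 `Cc1cc(N(C)Cc2ccccn2)n2nc(C)c(-c3ccccc3)c2n1` and compound 3 `Cc1cc(NCc2ccccn2)n2ncc(-c3cccc(Cl)c3)c2n1` share one core and were all examined in a physicochemical assay for solubility, read by HPLC, using the shake flask method, measured as kinetic solubility, with a stated time of 2 h, at pH 7.4; a lower number here means a less soluble compound, a higher number a more soluble compound. In this assay compound 2 gives 17500 nM. Compound 1 reaches only a limit of this assay, < 5000 nM. Compound 3 likewise returns only a limit, < 5000 nM. Where compound 3 stands is thus known only as the limit of < 5000 nM in this assay, at which 2 of the 3 values shown sit, not as a number. Compound 4 `Cc1cc(NCc2ccccn2)n2ncc(-c3cc(F)c(F)c(F)c3)c2n1` differs from compound 3 by 3,4,5-trifluorophenyl in place of 3-chlorophenyl on an aromatic carbon. For the measured compounds named here, no step between measured compounds is at hand, so no measured size guides this change; the expectation is for no shift beyond the scatter. The step from compound 3 to compound 4 is expected to be a step that the limit leaves unreadable from compound 3 to compound 4. Compound 4 is estimated at 3000 nM, ranging from 800 nM to 12000 nM.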

Compound 4, solubility: < 5000 nM
Compound 4 ended at the assay's limit; the forecaster's own chance of this, stated with the estimate: 65%; the middle value is on the limit's open side.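

No step can be read from compound 3 to compound 4, as both values are limits and not numbers: the limit of < 5000 nM in this assay, at which 3 of the 4 values shown sit. The compounds shown leave open whether 3,4,5-trifluorophenyl in place of 3-chlorophenyl shifts the reading in this assay at all.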